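Shared core series: aryl and benzyl amines at the exocyclic nitrogen

The source may report more compounds than this note shows. Statements on the series, on what has been measured and on what is new or still open speak of the compounds shown alone.

Compound 3 `N[C@@H]1CCCN(c2cc(NCc3ccccc3)n3nccc3n2)C1` in an assay on isolated protein for inhibition of Dipeptidyl peptidase 9 (Homo sapiens) (a lower number here means a stronger inhibitor, a higher number a weaker inhibitor), gives only a limit, > 100000 nM, and not a number. Compound 1 `N[C@@H]1CCCN(c2cc(Nc3cc(Cl)ccn3)n3nccc3n2)C1` in this assay likewise gives only a limit, > 50000 nM. Compound 2 `Cc1ccc(Nc2cc(N3CCNCC3)nc3ccnn23)c(C)c1` also stands at a limit in this assay, > 100000 nM. None of the three values shown is a number, so compound 3 cannot be placed relative to the other two; the step that the two limits leave unreadable from compound 1 to compound 3 is unreadable since both ends are limits, as are the lines the limit of > 100000 nM in this assay, at which 2 of the 3 values shown sit, and (the limit of > 50000 nM in this assay, at which 1 of the 3 values shown sits).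

Compound 4 `Cc1ccc(Nc2cc(N3CCC[C@@H](N)C3)nc3ccnn23)c(C)c1` differs from compound 3 as follows: 2,4-dimethylphenyl in place of benzyl on a nitrogen on an aromatic ring. The same 2,4-dimethylphenyl group on the same nitrogen is already present in compound 2, whose value is a limit, and the 3-aminopiperidine of compound 4 is already present in compounds 1 and 3, whose values are limits. Going by the values given here, no measured step in this assay gives a readable size, so no direction beyond the scatter can be derived, and compound 4 is expected to sit at a limit again, with an expected step that the limit leaves unreadable from compound 3 to compound 4. The estimate for compound 4 is 150000 nM, with a range from 30000 nM to 1000000 nM.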

Compound 4, half-maximal inhibitory concentration: > 100000 nM
Compound 4: only a limit was reported; the forecaster's own chance of this, stated with the estimate: 85%; the middle value does not contradict the limit.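

In this assay compound 4 gives only a limit, > 100000 nM; its steps from compound 1, compound 2 and compound 3 cannot be read. The compounds shown leave open which group, on a nitrogen on an aromatic ring or on an aromatic carbon, would give a number rather than a limit in this assay.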